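Adding a fluoro to the ring on the amide nitrogen

The source may hold more compounds than are shown below. What is called first, only, known or untested is meant among the compounds shown, and "the series" means these compounds.

For the measured compounds named here, compound 2 `O=C(NCCCCc1ccccc1)c1cccc(C2SCC(=O)N2c2ccccc2)c1` has the lowest of the two numbers so far in a functional assay on MG-63 cells (Homo sapiens) for inhibition, read by CCK-8 assay, with a stated time of 72 h, tested at 1 uM (on this read-out lower numbers stand for less inhibition and higher numbers for more inhibition at the one concentration tested (going by the name of the read-out)), where compound 2 gives 89%; compound 1 `COc1cc(F)ccc1N1C(=O)CSC1c1cccc(C(=O)NCCCCc2ccccc2)c1` gives 92%. The step of a number 3 percentage points lower from compound 1 to compound 2 (within the scatter), which also changed the ring on this nitrogen, stayed within the scatter. Compound 3 `O=C(NCCCCc1ccccc1)c1cccc(C2SCC(=O)N2c2ccccc2F)c1` differs from compound 2 by fluoro in place of hydrogen on an aromatic carbon. Because a number 3 percentage points lower from compound 1 to compound 2 (within the scatter) changed little, only a small shift, if any, is expected for compound 3 in this assay, a step of no change at the digits printed from compound 2 to compound 3 (within the scatter). Compound 3 is therefore estimated at 89%, with a range from 78% to 96%.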

Compound 3, a percentage reported as inhibition, at one concentration (the size of the read-out at that concentration, not a potency): 92%
Beside the measured number, compound 3's estimate is 3 percentage points below it, within the range that was stated.
By their numbers in this assay, from the lowest: compounds 2, 1 and 3 (each within the scatter of the next).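

In this assay, adding a fluoro ortho to a large group on the phenyl ring gives a number 3 percentage points higher from compound 2 to compound 3 (within the scatter), so the two compounds cannot be told apart. Placing 2-fluorophenyl where 4-fluoro-2-methoxyphenyl stood gives no change at the digits printed from compound 1 to compound 3 (within the scatter), so these three rings on the amide-type nitrogen also read alike at this single concentration. No measurement shown here offers an explanation for these results. Still open, from the compounds shown here alone, is whether an amine or a carboxylic acid on this ring would give a clearly different number, and whether these three compounds would separate at lower concentrations.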